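Chain Extension on a Urea-Linked Sulfonate Ester

A few compounds are considered here, and "the series" means these few. Any claim that something is new, unique, unknown or untested is made for them only; others in the source may bear on it.

Measured so far, in a functional assay on HT-29 cells (Homo sapiens) for antiproliferative activity, read by sulforhodamine B assay, with a stated time of 48 h; on this read-out higher numbers stand for weaker inhibition and lower numbers for stronger inhibition:
compound 1, `CCCC(=O)Nc1cccc(S(=O)(=O)Oc2ccccc2C(C)C)c1`, gives 13000 nM
compound 2, `CCCCCC(=O)Nc1cccc(S(=O)(=O)Oc2ccccc2C(C)C)c1`, gives 19000 nM
compound 3, `CCCNC(=O)Nc1ccc(S(=O)(=O)Oc2ccccc2C(C)C)cc1`, gives 6300 nM

Compound 1 and compound 2 share a core and differ only by ethyl in place of hydrogen on a saturated chain carbon, three bonds along the chain from a carbonyl carbon. That change gave a 1.5-fold higher number from compound 1 to compound 2 (0.16 log units; within the scatter), so the two numbers cannot be told apart. Compound 3 stands on a different core; the difference between the two cores is not broken down here. Its number is the lowest of the three, and its steps to compound 1 and compound 2 both lie beyond the scatter, so among the measured compounds compound 3 shows the strongest inhibition in this assay.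

Compound 4, `CCCCCNC(=O)Nc1ccc(S(=O)(=O)Oc2ccccc2C(C)C)cc1`, has not been measured. It differs from compound 3 by ethyl in place of hydrogen on a saturated chain carbon, three bonds along the chain from an amide-type nitrogen. Among the compounds with values here, this is the same kind of change as the one from compound 1 to compound 2, not the same: there the ethyl entered three bonds along the chain from a carbonyl carbon, here it enters three bonds along the chain from an amide-type nitrogen. Within the data shown here, with only one earlier example, the expectation rests on that single step from compound 1 to compound 2, a 1.5-fold higher number from compound 1 to compound 2 (0.16 log units; within the scatter), which stayed within the scatter. A step of similar size is expected from compound 3 to compound 4, namely a 1.4-fold higher number from compound 3 to compound 4 (0.15 log units; within the scatter). On that basis compound 4 is estimated at 9000 nM in this assay, with a likely range from 4500 nM to 18000 nM.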

Compound 4, half-maximal inhibitory concentration: 4900 nM
Estimate against measurement, compound 4: 1.8-fold (0.26 log units) above, within the range that was stated.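

In this assay, the change from propyl to pentyl on the core of compound 3 gave a 1.3-fold lower number from compound 3 to compound 4 (0.11 log units; within the scatter), so these two numbers cannot be told apart and the longer chain leaves the result where it was. Set beside the earlier step on the other core, the new step does not differ from it: the same change on two cores in this assay, a 1.5-fold higher number (0.16 log units; within the scatter) from compound 1 to compound 2 and a 1.3-fold lower number (0.11 log units; within the scatter) from compound 3 to compound 4, 1.9-fold (0.27 log units) apart, within the scatter of two such steps. This shows that, for these two pairs, the same chain extension had no effect that can be separated from the scatter on either core, and the opposite directions of the two steps carry no meaning; it does not show a general rule, since two small steps on two cores are a thin basis, and they say nothing about how a change with a large effect would carry from one core to the other.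

The compounds shown leave open whether a longer chain than pentyl, or a chain ending in an amine or a carboxylic acid, would move the number on either core. They also leave open which part of the difference between the two cores goes with the lower number of compound 3, since no pair shown differs in that one place alone.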